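Removing One Chloro From the Core: Expecting Compound 3

The source may hold more compounds than are shown below. What is called first, only, known or untested is meant among the compounds shown, and "the series" means these compounds.

Measured compounds:
compound 1, `ClCc1cccc(Cn2cnc3nc(Cl)nc(Cl)c32)c1`: "not determined" (no result reported)
compound 2, `ClCc1ccccc1Cn1cnc2c(Cl)ncnc21`: 4170 nM

Compound 1 carries two chloro groups on its core. In a functional assay on SK-OV-3 cells (Homo sapiens) for cytotoxicity, read by sulforhodamine B assay, with a stated time of 48 h (a higher number here means a weaker inhibitor of growth, a lower number a stronger inhibitor of growth), compound 1 has "not determined" (no result reported), so no number places it. Compound 2, with a single chloro on the same core and a different arrangement of its side arm, gives 4170 nM in this assay. Compound 3, `ClCc1cccc(Cn2cnc3ncnc(Cl)c32)c1`, keeps the side arm of compound 1 but loses one chloro: hydrogen in place of chloro on an aromatic carbon. Among the compounds with values here, compound 1 has no number, so the size and direction of the step to compound 3 in this assay cannot be judged from it; the only anchor is compound 2, which shares a single chloro on the core. Given that compound 2 gives 4170 nM in this assay, compound 3 is expected at an estimated 4500 nM, from 1200 nM to 18000 nM.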

Compound 3, concentration for 50% growth inhibition: 10700 nM
The estimate for compound 3 lay 2.4-fold (0.38 log units) below the measured number; the measured number falls inside the stated range.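

Within the data shown here, compound 1 has no number in this assay, so no step from it to compound 3 can be read. The compounds shown leave open whether losing that chloro strengthens or weakens growth inhibition. Nothing else given here bears on this result.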